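Swapping a methoxyphenyl for a furan on a weak core

The source may report more compounds than this note shows. Statements on the series, on what has been measured and on what is new or still open speak of the compounds shown alone.

Compound 1 `COc1ccccc1/C=C1/C(C)=C(CC(=O)O)c2cc(F)ccc21` is, on the numbers shown, the reference point of this small set: in a functional assay on SW480 cells (Homo sapiens) for antiproliferative activity (a lower number here means a stronger inhibitor, a higher number a weaker inhibitor), compound 1 gives 850000 nM, the only figure for it, while a further reading of the same compound came back without a single number. Compound 2 `CC1=C(CC(=O)O)c2cc(F)ccc2/C1=C\c1ccc(C)o1`, which carries a different ring on the same core, was measured more than once in this assay, where compound 2 gives 380000 nM; 80000 nM (2 entries), and its readings, (the several entries of compound 2 in this assay, 380000 nM; 80000 nM (2 entries)), spread widely, so what its values show is a weaker-inhibitor range that sits below that of compound 1.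

Compound 3 `CC1=C(CC(=O)O)c2cc(F)ccc2/C1=C\c1ccoc1` has not yet been measured. It is built from compound 1 by a single change: furan-3-yl in place of 2-methoxyphenyl on a double-bonded chain carbon bound to a double-bonded ring carbon. The piece therefore follows the step from compound 1 to compound 3 in this assay. Among the compounds with values here, with no measured pair of this kind to lean on, the expectation is a modest move toward a stronger inhibitor, at the edge of the usual scatter, as a 2.8-fold lower number from compound 1 to compound 3 (0.45 log units; beyond the scatter). Compound 3 is thus estimated at 300000 nM, within a range from 80000 nM to 1000000 nM.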

Compound 3, half-maximal inhibitory concentration: 400000 nM
Beside the measured number, compound 3's estimate is 1.3-fold (0.12 log units) below it; the range from low to high includes it.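

In this assay, the new result gives a 2.1-fold lower number from compound 1 to compound 3 (0.33 log units; beyond the scatter). It shows that at this place, on a double-bonded chain carbon bound to a double-bonded ring carbon, a five-membered aromatic ring with 1 hetero atom can replace a six-membered aromatic ring of carbon only with a modest gain and no loss. Compound 2 had hinted at this with a different ring on the same core, but it differs from compound 1 in more than the ring's size and its readings lie far apart, whereas compound 3 gives a clean single-change comparison: the several entries of compound 2 in this assay, 380000 nM; 80000 nM (2 entries)

The step remains modest and rests on one value for compound 3, so this change alone does not turn the shared core into a strong inhibitor. The swap also removes the methoxy group and changes the ring at the same time, so the compounds shown leave open which of the two matters, a question that a plain phenyl ring could help to separate, and whether a pyridine ring or a phenyl ring carrying an amine would move the number further.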